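A Thiazole Replaces the Phenol in a Cytotoxic Enol

The source may report more compounds than this note shows. Statements on the series, on what has been measured and on what is new or still open speak of the compounds shown alone.

Going by the values given here, compound 1 `COC1=C(C)C(=O)/C(=C(O)/C=C/c2ccc(O)cc2)C(=O)C1(C)C` is the only compound in this small set with a number attached: in a functional assay on 1A9 cells (Homo sapiens) for cytotoxicity (a higher number here means that more compound is needed for the effect, a lower number that less compound is needed), compound 1 gives 2.9 ug/mL. Compound 2 `COC1=C(C)C(=O)/C(=C(O)/C=C/c2ccc(C)cc2)C(=O)C1(C)C` belongs to the same series but in this assay compound 2 has only "not determined" (no result reported). Compound 3 `COC1=C(C)C(=O)/C(=C(O)/C=C/c2cc(C)cc(C)c2)C(=O)C1(C)C` also belongs to the series, and in this assay compound 3 likewise has only "not determined" (no result reported). Compound 4 `COC1=C(C)C(=O)/C(=C(O)/C=C/c2nccs2)C(=O)C1(C)C` differs from compound 1 in one place: 1,3-thiazol-2-yl in place of 4-hydroxyphenyl on a double-bonded chain carbon bound to a double-bonded chain carbon. Among the compounds with values here, no step between two measured compounds is available, so the expectation for compound 4 rests on compound 1 and its value of 2.9 ug/mL alone. The step of a 1.7-fold higher number from compound 1 to compound 4 (0.24 log units; within the scatter) is expected to be small, leaning toward somewhat more compound being needed, and close to the usual scatter. Compound 4 is therefore estimated at 5 ug/mL in this assay, within a range from 1.5 ug/mL to 15 ug/mL.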

Compound 4, concentration for half-maximal effect: 3.5 ug/mL
Estimate against measurement, compound 4: 1.4-fold (0.15 log units) above, and the stated range covers the measured number.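

In this assay the exchange of 4-hydroxyphenyl for 1,3-thiazol-2-yl gives a 1.2-fold higher number from compound 1 to compound 4 (0.08 log units; within the scatter) and so leaves the two compounds indistinguishable. This place on the chain therefore accepts a five-membered aromatic ring with 2 hetero atoms and 0 hydrogen-bond donors without a readable change in this read-out. Nothing available explains this result. From the compounds shown here alone, whether the same tolerance extends to a pyridine ring, or to a chain ending in an amine or a carboxylic acid at this place, remains open.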